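Thiophene Attachment Isomers on a Ribosyl Core

The source may report more compounds than this note shows. Statements on the series, on what has been measured and on what is new or still open speak of the compounds shown alone.

Compound 1 `O=c1[nH]cnc2c1c(-c1cc3ccccc3o1)cn2[C@@H]1O[C@H](CO)[C@@H](O)[C@H]1O`: > 20000 nM
Compound 2 `CN(C)c1ncnc2c1c(-c1cc3ccccc3o1)cn2[C@@H]1O[C@H](CO)[C@@H](O)[C@H]1O`: > 20000 nM
Compound 3 `O=c1[nH]cnc2c1c(-c1ccsc1)cn2[C@@H]1O[C@H](CO)[C@@H](O)[C@H]1O`: 14500 nM

In a functional assay on CCRF-CEM cells (Homo sapiens), read by MTT assay, with a stated time of 72 h (a lower number here means a stronger inhibitor, a higher number a weaker inhibitor), compound 1 reaches only the assay limit, > 20000 nM. Compound 2 likewise reaches only the assay limit, > 20000 nM. For the measured compounds named here, compound 3 gives 14500 nM, the single actual number among the three. The step of an at least 1.3-fold lower number from compound 1 to compound 3 (0.13 log units; that floor lies within the scatter) is only a floor, since it rests on (the limit of > 20000 nM in this assay, at which 2 of the 3 values shown sit). Compound 4 `O=c1[nH]cnc2c1c(-c1cccs1)cn2[C@@H]1O[C@H](CO)[C@@H](O)[C@H]1O` differs from compound 3 by thiophen-2-yl in place of thiophen-3-yl on an aromatic carbon. Going by the values given here, no measured step exchanges thiophen-3-yl for thiophen-2-yl, and the one step at this carbon is a floor within the scatter, so nothing points in either direction. The expected step is a 1.1-fold lower number from compound 3 to compound 4 (0.05 log units; within the scatter), nothing beyond the scatter. Compound 4 is estimated at 13000 nM, ranging from 5000 nM to 30000 nM.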

Compound 4, half-maximal inhibitory concentration: > 20000 nM
Compound 4: only a limit was reported; the forecaster's own chance of this, stated with the estimate: 35%; middle value at least 1.5-fold (0.18 log units) away from the limit.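

In this assay compound 4 gives only a limit, so swapping thiophen-3-yl for thiophen-2-yl at this carbon yields an at least 1.3-fold higher number from compound 3 to compound 4 (0.13 log units; that floor lies within the scatter), and the two attachment isomers cannot be told apart. For the compounds shown here, compound 3 remains the only compound here with an actual number. The step between compound 1 and compound 4 cannot be read, because both values stop at the same limit: the limit of > 20000 nM in this assay, at which 3 of the 4 values shown sit.

The compounds shown leave open whether a furan-2-yl group at this carbon, or an amine or a carboxylic acid on the thiophene ring, would give a measurable number.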